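Quinoline Amine Variation and Melanin-Concentrating Hormone Receptor 1 Binding

The source may report more compounds than this note shows. Statements on the series, on what has been measured and on what is new or still open speak of the compounds shown alone.

Measured compounds:
Compound 1, `CN(c1ccc2cc(NC(=O)CCc3ccc(C(F)(F)F)cc3)ccc2n1)C1CCCCC1`, gives 18 nM in an assay on isolated protein for displacement of a labelled ligand from melanin-concentrating hormone receptor 1 (Homo sapiens); on this read-out lower numbers stand for stronger inhibition and higher numbers for weaker inhibition.
Compound 2, `CN(C)c1ccc2cc(NC(=O)CCc3ccc(C(F)(F)F)cc3)ccc2n1`, gives 13 nM.
Compound 3, `NC1CCN(c2ccc3cc(NC(=O)CCc4ccc(C(F)(F)F)cc4)ccc3n2)C1`, gives 12 nM.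

Compound 1 has the highest number of the three, but its neighbours lie close: a 1.4-fold lower number from compound 1 to compound 2 (0.14 log units; within the scatter) and a 1.5-fold lower number from compound 1 to compound 3 (0.18 log units; within the scatter), both within the scatter. The step to compound 4, `O=C(CCc1ccc(C(F)(F)F)cc1)Nc1ccc2nc(N3CC4CC3CN4)ccc2c1`, replaces the amine group on the shared core: a group of 7 heavy atoms (5 carbon, 2 nitrogen; 2 five-membered non-aromatic rings with 1 hetero atom each) in place of a group of 8 heavy atoms (7 carbon, 1 nitrogen; one six-membered non-aromatic ring of carbon only), on an aromatic carbon. The earlier steps shown here bear on this, since a 1.1-fold lower number from compound 2 to compound 3 (0.03 log units; within the scatter) and the two steps from compound 1 were all within the scatter despite amine groups of differing size and donor count. No change beyond the scatter is therefore expected, and compound 4 is estimated at 13 nM, range 5 nM to 35 nM, an expected 1.4-fold lower number from compound 1 to compound 4 (0.14 log units; within the scatter).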

Compound 4, half-maximal inhibitory concentration: 210 nM
Compound 4: the middle estimate sits 16-fold (1.21 log units) below what was measured, outside the stated range (above it).
By their numbers in this assay, from the lowest: compounds 3, 2 and 1 (each within the scatter of the next); then compound 4.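

In this assay the amine on this aromatic carbon next to the ring nitrogen is not freely exchangeable: the group with 2 five-membered non-aromatic rings gives large steps (a 12-fold higher number from compound 1 to compound 4 (1.07 log units; beyond the scatter)), (a 16-fold higher number from compound 2 to compound 4 (1.21 log units; beyond the scatter)) and (an 18-fold higher number from compound 3 to compound 4 (1.24 log units; beyond the scatter)), where the earlier amines stayed within the scatter. Heavy-atom count alone does not order these values, since the group in compound 4 is smaller than that in compound 1 yet larger than that in compound 3. Nothing at hand explains this loss. Going by these compounds, whether the second ring is what matters stays open, as does how a piperazin-1-yl or morpholin-4-yl group would read here.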